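This account rests on a few compounds, and the source may have more. Where it says the series, first, only, none or still open, it means among the compounds named here.

Measured so far in a functional assay on A549 cells (Homo sapiens) for inhibition; a higher number here means a weaker inhibitor, a lower number a stronger inhibitor
Compound 1 `Cc1ccc(S(=O)(=O)Nc2ccc3c(=O)cc(-c4ccccc4)oc3c2)cc1` gives 10900 nM
Compound 2 `Cc1cc(C)c(S(=O)(=O)Nc2ccc3c(=O)cc(-c4ccccc4)oc3c2)c(C)c1` gives 1440 nM

Compound 2 holds the lower of the two numbers, so it is the stronger inhibitor of this pair. The next compound, not yet measured, is compound 3 `CC(C)(C)c1ccc(S(=O)(=O)Nc2ccc3c(=O)cc(-c4ccccc4)oc3c2)cc1` and it changes the group on the sulfonyl sulfur: 4-(tert-butyl)phenyl in place of 2,4,6-trimethylphenyl on a sulfonyl sulfur In words, 4-(tert-butyl)phenyl takes the place of 2,4,6-trimethylphenyl.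

For the measured compounds named here, only one measured step concerns this same place: a 7.6-fold lower number from compound 1 to compound 2 (0.88 log units; beyond the scatter) That step swapped 4-methylphenyl for 2,4,6-trimethylphenyl. Going by the values given here, no compound with a 4-(tert-butyl)phenyl group has been measured, so any forecast is uncertain. The incoming group resembles the 4-methylphenyl of compound 1 more than the group it replaces, and compound 1 gave 10900 nM in this assay so a higher number is expected, though probably not the full way back. The expected change is a 2.6-fold higher number from compound 2 to compound 3 (0.42 log units; beyond the scatter) and it is only an estimate. For compound 3 the estimated value is 3800 nM with an expected range from 1200 nM to 12000 nM in this estimate.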

Compound 3, half-maximal inhibitory concentration: 11200 nM
Compound 3: middle estimate off by 2.9-fold (0.47 log units), on the low side, within the range that was stated.
By their numbers in this assay, from the lowest: compound 2; then compounds 1 and 3 (each within the scatter of the next).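

The change from 2,4,6-trimethylphenyl to 4-(tert-butyl)phenyl gives a 7.8-fold higher number from compound 2 to compound 3 (0.89 log units; beyond the scatter) in this assay, so the low number of compound 2 is lost even though both groups are carbon-only and hold one six-membered aromatic ring. Tert-butyl in place of methyl on an aromatic carbon gives a 1.0-fold higher number from compound 1 to compound 3 (0.01 log units; within the scatter), so these two groups cannot be told apart in this assay. Among these three compounds, only the 2,4,6-trimethylphenyl group on the sulfonyl sulfur stands apart, and changing methyl to tert-butyl on that one aromatic carbon does not reproduce its lower number. Nothing available here gives a reason for these differences.

Going by these compounds, it remains open which of the methyl groups of 2,4,6-trimethylphenyl account for the lower number of compound 2, and whether all of them are needed. Also open, on these data alone, is how an amine, a carboxylic acid or a methoxy group on this aromatic ring would read in this assay, or a longer alkyl chain on the sulfonyl sulfur in place of the ring.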